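Nitro to methylamino on the six-membered ring: compound 4

The compounds below may be only part of what the source reports. "The series", "measured", "known", "first", "only" and "open" are said of these compounds alone.

Compound 1 `CCCCN(CCC)c1cc(C)nc2c(-c3ncc(C(F)(F)F)cc3Cl)c(C)nn12` gives 1.2 nM in an assay on isolated protein for binding affinity to corticotropin-releasing factor receptor 1 (Homo sapiens); on this read-out lower numbers stand for stronger inhibition and higher numbers for weaker inhibition. Among the compounds with values here, compound 2 `CCCN(Cc1ccccc1)c1cc(C)nc2c(-c3ncc(C(F)(F)F)cc3Cl)c(C)nn12` gives 1.7 nM in this assay; the only single-site step among the measured compounds, a 1.4-fold higher number from compound 1 to compound 2 (0.15 log units; within the scatter), concerns the chain on the ring nitrogen and stays within the scatter. Within the data shown here, compound 3 `CCCN(CCC)c1cc(C)nc2c(-c3ncc([N+](=O)[O-])cc3C)c(C)nn12` gives 9.1 nM in this assay, the highest number of the three; compound 2 and compound 1 both lie below it by more than the scatter, but compound 3 differs from each of them in two groups on the six-membered aromatic ring at once, so no single-site step is available for that ring.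

Compound 4 `CCCN(CCC)c1cc(C)nc2c(-c3ncc(NC)cc3C)c(C)nn12` is the next point: methylamino in place of nitro on an aromatic carbon. Among the measured compounds shown here, no measured step bears on this change, neither on these groups nor on this position; the step from compound 1 to compound 2 is at a different site and was within the scatter. The expectation therefore rests on compound 3 alone, with the direction open. A moderate step, a 1.6-fold higher number from compound 3 to compound 4 (0.22 log units; within the scatter), is expected, weaker rather than stronger, since the two lower numbers in the series carry different substitution on that ring. Compound 4 is estimated at 15 nM in this assay, with a range from 4 nM to 60 nM.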

Compound 4, inhibition constant: 40 nM
Estimate against measurement, compound 4: 2.7-fold (0.43 log units) below, within the range that was stated.
By their numbers in this assay, from the lowest: compounds 1 and 2 (each within the scatter of the next); then compound 3; then compound 4.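

In this assay, within the data shown here, the exchange of nitro for methylamino gives a 4.4-fold higher number from compound 3 to compound 4 (0.64 log units; beyond the scatter) and so provides the first single-site reading on the six-membered aromatic ring. This step lies beyond the scatter and runs toward weaker inhibition, which shows that the group para to a large group and meta to a methyl group is not interchangeable, at least for this pair. The exchange alters the heavy atoms, the hydrogen-bond donors and the hydrogen-bond acceptors together, and nothing at hand ties the step to any one of these or explains its direction.

Still open, going by these compounds, is how an unsubstituted amino group, a dimethylamino group or a methoxy group on the same carbon would compare with nitro and methylamino. Compound 1 and compound 2 carry trifluoromethyl on that ring, but they also carry chlorine where compound 3 and compound 4 carry methyl and differ from them in the chain on the amine nitrogen, so the contribution of each group to their lower numbers remains unseparated.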